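The compounds below may be only part of what the source reports. "The series", "measured", "known", "first", "only" and "open" are said of these compounds alone.

Measured compounds in a functional assay on DLD-1 cells (Homo sapiens) for cytotoxicity, read by MTT assay, with a stated time of 48 h; on this read-out higher numbers stand for weaker inhibition and lower numbers for stronger inhibition:
- compound 1 `CCCCCCCCOc1ccc2c(Cl)ccnc2c1`: 4500 nM
- compound 2 `Clc1ccnc2cc(OCc3ccccc3)ccc12`: 3270 nM
- compound 3 `CN(C)CCCNc1ccnc2cc(OCc3ccc(F)cc3)ccc12`: 2540 nM

The three numbers sit close together. Compound 1 with 4500 nM is nominally the uppermost of the set, but its gap to compound 2 and its gap to compound 3 both fall inside the usual scatter of this assay, so no ranking among the three can be read from these data.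

Compound 4 `Clc1ccnc2cc(OCCCc3ccccc3)ccc12` is not yet measured. Against compound 1 the change is phenyl in place of pentyl on a saturated chain carbon, three bonds along the chain from an oxygen on an aromatic ring. Within the data shown here, no step between measured compounds isolates this change, so the expectation rests on the spread seen so far: compound 2, which also carries an aromatic ring on the chain off the ring oxygen, gives 3270 nM, indistinguishable from compound 1. The step from compound 1 to compound 4 is therefore expected to be a 1.3-fold lower number from compound 1 to compound 4 (0.10 log units; within the scatter), that is, nothing beyond the scatter in either direction. Compound 4 is estimated at 3600 nM, with a plausible range from 1500 nM to 9000 nM.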

Compound 4, half-maximal inhibitory concentration: 2140 nM
The estimate for compound 4 lay 1.7-fold (0.23 log units) above the measured number, and the stated range covers the measured number.
By their numbers in this assay, from the lowest: compounds 4, 3, 2 and 1 (each within the scatter of the next, the first and the last beyond it).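

In this assay, among these compounds, phenyl in place of pentyl on a saturated chain carbon, three bonds along the chain from an oxygen on an aromatic ring, gives a 2.1-fold lower number from compound 1 to compound 4 (0.32 log units; beyond the scatter) and is the only single-place step so far. It is also the only gap in the set that clears the scatter, so the compounds can now be told apart at this position, though only modestly and on one pair. Nothing measured here bears on why the number moves with this change.

Only pentyl and phenyl have been compared at this place, so one step cannot show whether the ring itself matters or whether any other group would do the same. A carboxylic acid, a hydroxyl group or a longer chain at this place remains an open comparison.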